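Carbamoyl for Fluoro on the Aryl Ring of Compound 1

The source may report more compounds than this note shows. Statements on the series, on what has been measured and on what is new or still open speak of the compounds shown alone.

Compound 1 `CCOC(=O)CC1C(C(=O)OCC)=C(N)Oc2ccc(-c3cccc(F)c3)cc21` stands at the weak end of the three measured compounds. In a functional assay on HL-60 cells (Homo sapiens) for cytotoxicity, read by CellTiter-Blue, with a stated time of 48 h (a higher number here means a weaker inhibitor, a lower number a stronger inhibitor), compound 1 gives 76400 nM, the highest number of the set. Compound 2 `C#CCOC(=O)CC1C(C(=O)OCC#C)=C(N)Oc2ccc(-c3cccc(N)c3)cc21` gives 1240 nM in this assay, and compound 3 `C#CCOC(=O)CC1C(C(=O)OCC#C)=C(N)Oc2ccc(-c3cccc(NC)c3)cc21` gives 880 nM; both differ from compound 1 in more than one place, so their values show only that the set spans a wide range. Within the data shown here, the one step between neighbours, a 1.4-fold lower number from compound 2 to compound 3 (0.15 log units; within the scatter), concerns a change on a nitrogen and does not reach the aromatic carbon in question.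

Compound 4 `CCOC(=O)CC1C(C(=O)OCC)=C(N)Oc2ccc(-c3cccc(C(N)=O)c3)cc21` is the unmeasured member. It differs from compound 1 as follows: carbamoyl in place of fluoro on an aromatic carbon. Among the measured compounds shown here, no measured step shows what a change on this aromatic carbon does to the number in this assay, since compounds 2 and 3 carry different esters as well as a different aryl substituent. The expectation therefore rests on little: a carbamoyl group brings one hydrogen-bond donor and one acceptor where fluoro brought none, and compounds 2 and 3, which also carry a donor on that ring, sit far below compound 1. The estimated step is a 2.2-fold lower number from compound 1 to compound 4 (0.34 log units; beyond the scatter), a lower number expected but held with wide uncertainty. Compound 4 is estimated at 35000 nM, within a range from 8000 nM to 120000 nM.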

Compound 4, half-maximal inhibitory concentration: 5400 nM
Compound 4: middle estimate off by 6.5-fold (0.81 log units), on the high side; measured number outside the range, below it.
By their numbers in this assay, from the lowest: compounds 3 and 2 (each within the scatter of the next); then compound 4; then compound 1.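

Exchanging fluoro for carbamoyl on this aromatic carbon, meta to a large group, gives a 14-fold lower number from compound 1 to compound 4 (1.15 log units; beyond the scatter) in this assay, so this position, on which no earlier step fell, is shown to be one where a single change can move the number well beyond the scatter. The esters and the rest of the core of compound 1 stay the same in compound 4, which ties this step to the change from 3-fluorophenyl to 3-carbamoylphenyl alone, something the comparisons involving compound 2 and compound 3, with their different esters, could not do. Nothing at hand bears on why the number moves this far.

The compounds shown leave open which part of the carbamoyl group the step depends on, and whether a carboxylic acid, a nitrile or a methyl amide on the same carbon would give a similar number. From the compounds shown here alone, it also remains open whether the carbamoyl group would give a step of similar size on the core carrying the esters of compound 2 and compound 3.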